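The compounds below may be only part of what the source reports. "The series", "measured", "known", "first", "only" and "open" are said of these compounds alone.

Compound 3 `COc1cc(-c2nn(-c3cccc(NC(=O)c4ccc(Cl)c(C(F)(F)F)c4)c3)cc2-c2ccncc2)ccc1Cl` carries the highest number in a functional assay on SW-620 cells (Homo sapiens) for inhibition, read by sulforhodamine B assay, with a stated time of 48 h (a lower number here means a stronger inhibitor of growth, a higher number a weaker inhibitor of growth), among the three compounds measured, giving 4750 nM. Compound 1 `COc1cc(-c2nn(-c3cccc(NC(=O)c4cccc(C(F)(F)F)c4)c3)cc2-c2ccncc2)ccc1Cl` gives 2310 nM, and compound 2 `COc1cc(-c2nn(-c3cccc(NC(=O)Nc4ccc(Cl)c(Cl)c4)c3)cc2-c2ccncc2)ccc1Cl` gives 1590 nM. Going by the values given here, the step of a 2.1-fold higher number from compound 1 to compound 3 (0.31 log units; beyond the scatter) and the step of a 3.0-fold higher number from compound 2 to compound 3 (0.48 log units; beyond the scatter) are both beyond the scatter, so compound 3 stands apart as the weakest growth inhibitor of the three so far.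

Compound 4 `COc1cc(-c2nn(-c3cccc(NC(=O)Nc4ccc(Cl)c(C(F)(F)F)c4)c3)cc2-c2ccncc2)ccc1Cl` differs from compound 3 in one place: (4-chloro-3-(trifluoromethyl)phenyl)amino in place of 4-chloro-3-(trifluoromethyl)phenyl on a carbonyl carbon. The aryl group is kept; only the amino link on the carbonyl carbon is new.

Among the compounds with values here, one measured step bears on this kind of change: a 1.5-fold lower number from compound 1 to compound 2 (0.16 log units; within the scatter), where an amino link entered on the carbonyl carbon, though there the aryl group changed at the same time. That step was within the scatter. The step of a 3.0-fold higher number from compound 2 to compound 3 (0.48 log units; beyond the scatter) combines the link change with the aryl change, so it cannot be separated into parts. On these grounds the link change alone is expected to give at most a small step, if anything toward a lower number, and not one clearly beyond the scatter.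

Compound 4 is therefore estimated at 3200 nM in this assay, with a range from 1400 nM to 7500 nM, an expected step of a 1.5-fold lower number from compound 3 to compound 4 (0.17 log units; within the scatter).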

Compound 4, concentration for 50% growth inhibition: 1290 nM
Estimate against measurement, compound 4: 2.5-fold (0.39 log units) above; measured number below the stated range.
By their numbers in this assay, from the lowest: compounds 4, 2 and 1 (each within the scatter of the next); then compound 3.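

Going by these compounds alone, with the aryl group held constant, the amino link on the carbonyl carbon gives a 3.7-fold lower number from compound 3 to compound 4 (0.57 log units; beyond the scatter) in this assay; this is the first step that isolates the link, and it shows that the link alone can shift the number beyond the scatter. With the link in place, trifluoromethyl in place of chloro on an aromatic carbon gives a 1.2-fold lower number from compound 2 to compound 4 (0.09 log units; within the scatter), so these two aryl groups are not separated at this position. Within the data shown here, the step of a 1.8-fold lower number from compound 1 to compound 4 (0.25 log units; within the scatter), which joins the amino link to the added chloro, also stays within the scatter, leaving compound 3 as the only compound apart from the others. No measurement at hand gives a cause for these steps.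

Still open, as far as these compounds go, is whether the amino link gives a step of similar size on 3-(trifluoromethyl)phenyl, where the aryl group carries no chloro. Also open, from the compounds shown here alone, is whether the amide hydrogen of the new link matters, which a methyl on that nitrogen or an oxygen in its place would test.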